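The compounds below may be only part of what the source reports. "The series", "measured", "known", "first", "only" and "open" are said of these compounds alone.

Measured compounds:
compound 1 `O=C(Nc1cccc(-n2cc(-c3ccncc3)c(-c3ccc(Cl)c(O)c3)n2)c1)Nc1cccc(C(F)(F)F)c1` with 15800 nM in a functional assay on SF-268 cells (Homo sapiens) for inhibition, read by sulforhodamine B assay, with a stated time of 48 h; a lower number here means a stronger inhibitor of growth, a higher number a weaker inhibitor of growth
compound 2 `COc1cc(-c2nn(-c3cccc(NC(=O)Nc4cc(C(F)(F)F)cc(C(F)(F)F)c4)c3)cc2-c2ccncc2)ccc1Cl` with 2430 nM
compound 3 `COc1cc(-c2nn(-c3cccc(NC(=O)Nc4cccc(C(F)(F)F)c4)c3)cc2-c2ccncc2)ccc1Cl` with 5430 nM

Among these three, compound 2 holds the lowest number: compound 3 stands nearest, a step of a 2.2-fold higher number from compound 2 to compound 3 (0.35 log units; beyond the scatter) away, and compound 1 lies furthest, with the largest gap to compound 2. The unmeasured compound 4 `O=C(Nc1cccc(-n2cc(-c3ccncc3)c(-c3ccc(Cl)c(O)c3)n2)c1)Nc1cc(C(F)(F)F)cc(C(F)(F)F)c1` is reached from compound 2 by a single change, (hydrogen in place of methyl on an oxygen on an aromatic ring), so that the 4-chloro-3-methoxyphenyl group becomes 4-chloro-3-hydroxyphenyl.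

Within the data shown here, one measured step bears directly on this: the reverse change, methyl in place of hydrogen on the same oxygen, gave a 2.9-fold lower number from compound 1 to compound 3 (0.46 log units; beyond the scatter). Read backwards, removing the methyl should therefore send the number upward by a modest amount, beyond the scatter. The other step, a 2.2-fold higher number from compound 2 to compound 3 (0.35 log units; beyond the scatter), concerns the trifluoromethyl and does not touch the oxygen, so it only locates compound 2 relative to compound 3.

Compound 4 is thus expected to be a weaker inhibitor of growth than compound 2, with an estimated step of a 2.9-fold higher number from compound 2 to compound 4 (0.46 log units; beyond the scatter). The estimate for compound 4 in this assay is 7000 nM, expected to fall between 3000 nM and 16000 nM.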

Compound 4, concentration for total growth inhibition: 2690 nM
Compound 4: the middle estimate sits 2.6-fold (0.42 log units) above what was measured; the whole stated range lies above it.
By their numbers in this assay, from the lowest: compounds 2 and 4 (each within the scatter of the next); then compound 3; then compound 1.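

In this assay, the change from methoxy to hydroxy on the aromatic ring, which had moved the number beyond the scatter on the core of compound 1, gives a 1.1-fold higher number from compound 2 to compound 4 (0.04 log units; within the scatter). The earlier step at this oxygen therefore does not reappear as a clear step on the second core, yet the two readings of the change cannot be told apart: the same change on two cores in this assay, a 2.9-fold lower number (0.46 log units; beyond the scatter) from compound 1 to compound 3 and a 1.1-fold lower number (0.04 log units; within the scatter) from compound 4 to compound 2, 2.6-fold (0.42 log units) apart, within the scatter of two such steps. Trifluoromethyl in place of hydrogen on the aromatic carbon gives a 5.9-fold lower number from compound 1 to compound 4 (0.77 log units; beyond the scatter), so that change now has a step beyond the scatter with hydroxy as well as with methoxy, and its two readings also agree within the scatter: the same change on two cores in this assay, a 2.2-fold higher number (0.35 log units; beyond the scatter) from compound 2 to compound 3 and a 5.9-fold higher number (0.77 log units; beyond the scatter) from compound 4 to compound 1, 2.6-fold (0.42 log units) apart, within the scatter of two such steps.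

The compounds shown leave open how an ethyl or a longer chain on this oxygen, or an amine in place of the hydroxy, would stand against compound 2 in this assay. As far as these compounds go, whether a fluorine or a nitrile in place of the chlorine on the same ring would shift the number, with either methoxy or hydroxy present, also remains open.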